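Hydroxy in place of methoxy on the methylphenyl ring

The source may report more compounds than this note shows. Statements on the series, on what has been measured and on what is new or still open speak of the compounds shown alone.

Compound 1 `Cc1cc(O)cc(-c2nn(CC#N)cc2-c2ccnc(-c3ccc(Oc4ccccc4)cc3)c2)c1` is the reference point: in a functional assay on ACHN cells (Homo sapiens) for inhibition, read by sulforhodamine B assay, with a stated time of 48 h (on this read-out lower numbers stand for higher toxicity in this test and higher numbers for lower toxicity in this test), compound 1 gives 33800 nM. Compound 2 `COc1cc(C)cc(-c2nn(CC#N)cc2-c2ccnc(-c3ccc(N(C)C)cc3)c2)c1` has no number of its own: in this assay compound 2 gives only > 100000 nM, a limit of the assay, this being (the limit of > 100000 nM in this assay, at which 1 of the 2 values shown sits). Compound 3 `Cc1cc(O)cc(-c2nn(CC#N)cc2-c2ccnc(-c3ccc(N(C)C)cc3)c2)c1` is compound 2 with hydrogen in place of methyl on an oxygen on an aromatic ring. Going by the values given here, no measured pair isolates this change, so the size of the step is open. Compound 1, which carries the hydroxy, gives 33800 nM, so a modest move toward higher toxicity is expected. Compound 3 is expected near 80000 nM, between 25000 nM and 300000 nM. The expected step is an at least 1.2-fold lower number from compound 2 to compound 3 (0.09 log units; that floor lies within the scatter).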

Compound 3, concentration lethal to 50% of the cells: > 100000 nM
Compound 3 gave a limit, no number (the forecaster's own chance of this, stated with the estimate: 45%); at least 1.2-fold (0.09 log units) between middle value and limit.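

In this assay compound 3 gives only a limit, > 100000 nM. The methoxy to hydroxy step cannot be read because both compounds sit at a limit: the limit of > 100000 nM in this assay, at which 2 of the 3 values shown sit. With the hydroxy kept, dimethylamino in place of phenoxy on an aromatic carbon gives an at least 2.9-fold higher number from compound 1 to compound 3 (0.47 log units; beyond the scatter), so the hydroxy alone does not carry the lower number of compound 1.

On these data alone, the effect of methoxy to hydroxy with phenoxy in place remains open. So does whether an amine such as piperidine in place of dimethylamino brings a number below the limit.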